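A Two-Ring Group Replaces Butyl in Compound 2

A few compounds are considered here, and "the series" means these few. Any claim that something is new, unique, unknown or untested is made for them only; others in the source may bear on it.

In an ADME assay on MDCK cells (Canis lupus familiaris) for cytotoxicity, read by MTT assay, with a stated time of 48 h (on this read-out higher numbers stand for lower toxicity in this test and lower numbers for higher toxicity in this test), compound 2 `CCCCCc1cn(CC2=C(Cl)c3ccc(-c4cccs4)nc3CC2)nn1` gives 50 ug/mL. Compound 1 `Fc1ccc(-c2cn(CC3=C(Cl)c4ccc(-c5cccs5)nc4CC3)nn2)cc1` gives 100 ug/mL, which matches compound 2 within the scatter. Compound 3 `ClC1=C(Cn2cc(C3CC3)nn2)CCc2nc(-c3cccs3)ccc21` gives > 300 ug/mL, which is a limit of the assay and not a number.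

Compound 4 `O=C1c2ccccc2C(=O)N1Cc1cn(CC2=C(Cl)c3ccc(-c4cccs4)nc3CC2)nn1` is compound 2 with one change: a group of 11 heavy atoms (8 carbon, 1 nitrogen, 2 oxygen; one five-membered non-aromatic ring with 1 hetero atom, one six-membered aromatic ring of carbon only) in place of a group of 4 heavy atoms (4 carbon; no ring), on a saturated chain carbon bound to an aromatic carbon. The entering group holds a five-membered non-aromatic ring and a six-membered aromatic ring of carbon only, and it sits on a saturated chain carbon bound to an aromatic carbon.

Among the compounds with values here, three measured steps bear on this change. Pentyl in place of 4-fluorophenyl gave a 2.0-fold lower number from compound 1 to compound 2 (0.30 log units; within the scatter). Cyclopropyl in place of pentyl gave an at least 6.0-fold higher number from compound 2 to compound 3 (0.77 log units; beyond the scatter), and cyclopropyl in place of 4-fluorophenyl gave an at least 3.0-fold higher number from compound 1 to compound 3 (0.47 log units; beyond the scatter). So only the compound with the small cyclopropyl group stands apart. Compound 4 carries a large group, as compound 1 does at 100 ug/mL, so no step beyond the scatter is expected. Within the data shown here, no measured compound carries this group, which keeps the range wide. The expected change is a 1.6-fold higher number from compound 2 to compound 4 (0.20 log units; within the scatter). For compound 4 the estimate is 80 ug/mL, with an expected range from 25 ug/mL to 300 ug/mL.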

Compound 4, half-maximal cytotoxic concentration: > 300 ug/mL
Compound 4: a limit, no number; the forecaster's own chance of this, stated with the estimate: 15%; at least 3.7-fold (0.57 log units) between middle value and limit.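

Putting the two-ring group in place of butyl gives an at least 6.0-fold higher number from compound 2 to compound 4 (0.77 log units; beyond the scatter) in this assay, so a large group at this place does not have to go with a low number. Until now only compound 3, with its small cyclopropyl, stood apart, which made group size look like the thing that sorted these compounds, but compound 4 goes against that reading: its entering group is larger than the groups of compound 1 and compound 2, yet compound 4 reaches the same limit as compound 3: the limit of > 300 ug/mL in this assay, at which 2 of the 4 values shown sit. That shared value is a limit of the assay and not a number, so compound 3 and compound 4 cannot be ranked against each other.

The compounds shown do not tell which part of the entering group matters: the two carbonyl groups, the six-membered aromatic ring, or the ring nitrogen that joins them to the saturated chain carbon. A plain benzyl group or an amine in the same place would help to separate these parts, and all of this rests on a single cell toxicity read-out.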